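The source may report more compounds than this note shows. Statements on the series, on what has been measured and on what is new or still open speak of the compounds shown alone.

In an ADME assay on microsomes from liver (Rattus norvegicus) for metabolic stability, read by LC-MS, using NADPH, with a stated time of 10 min, tested at 0.5 uM (a higher number here means that more of the compound is left, a lower number that less of the compound is left), compound 3 `CC(=O)Nc1cc(-c2ccc(OC[C@@H](N)CC(C)C)c(C)c2)ccn1` gives 99% and lies within the scatter of compound 2 `COC(=O)Nc1cc(-c2ccc(OC[C@@](C)(N)CC(C)C)cn2)ccn1` at 100%. Both stand clear of compound 1 `CC(=O)Nc1cc(-c2ccc(OC[C@@H](N)CC(C)C)c(F)c2)ccn1` at 80% on the low side. Compound 4 `CC(=O)Nc1cc(-c2ccc(OC[C@@H](N)CC(C)C)c(OC(F)(F)F)c2)ccn1` has not yet been measured. It differs from compound 3 by trifluoromethoxy in place of methyl on an aromatic carbon, ortho to a (2-amino-4-methylpentyl)oxy group (trifluoromethoxy in place of methyl on an aromatic carbon). Going by the values given here, only one measured step bears on this change: a number 19 percentage points higher from compound 1 to compound 3 (beyond the scatter) (methyl in place of fluoro on an aromatic carbon). Among the compounds with values here, that step shows that a single group on this carbon can move the read-out by a modest amount, but no measured compound carries trifluoromethoxy, so the support is thin. Compound 3 at 99% leaves little room for a rise, so any change is expected to be a fall. In this assay the expected step is a modest one, a number 14 percentage points lower from compound 3 to compound 4 (beyond the scatter) as estimated here. Compound 4 is estimated at 85% with 65% to 100% as its expected range.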

Compound 4, percent of the compound remaining: 80%
Compound 4: middle estimate off by 5 percentage points, on the high side, within the range that was stated.
By their numbers in this assay, from the lowest: compounds 1 and 4 (each within the scatter of the next); then compounds 3 and 2 (each within the scatter of the next).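

In this assay, replacing methyl with trifluoromethoxy on this aromatic carbon, ortho to a (2-amino-4-methylpentyl)oxy group, gives a number 19 percentage points lower from compound 3 to compound 4 (beyond the scatter), so a second group now falls short of methyl here. Trifluoromethoxy and fluoro cannot be told apart, with no change at the digits printed from compound 1 to compound 4 (within the scatter), which leaves methyl as the only one of the three groups on this carbon that gives the higher read-out. No measurement shown here explains why these groups separate in this way.

From the compounds shown here alone, it remains open whether chloro, methoxy or ethyl on this carbon would stay with methyl or fall with fluoro and trifluoromethoxy. Compound 2 differs from these compounds in more than one place, so it cannot show whether the same ranking holds on a different core.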